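The compounds below may be only part of what the source reports. "The series", "measured", "known", "first", "only" and "open" are said of these compounds alone.

In a physicochemical assay for solubility, in simulated intestinal fluid, measured as thermodynamic solubility, at pH 6.8 (a lower number here means a less soluble compound, a higher number a more soluble compound), compound 1 `NC1CCN(c2nc3c(c(Nc4ccc(C(F)(F)F)cc4)n2)CCN(c2ncccc2C(F)(F)F)CC3)C1` gives > 215 ug/mL, which is a limit of the assay and not a number. Compound 2 `CCC(CC)N1CCN(c2nc3c(c(Nc4ccc(C(F)(F)F)cc4)n2)CCN(c2ncccc2C(F)(F)F)CC3)CC1` gives 109 ug/mL, the higher of the two actual numbers, and compound 3 `CC(C)(C)OC(=O)N1CCCC(Nc2nc3c(c(Nc4ccc(C(F)(F)F)cc4)n2)CCN(c2ncccc2C(F)(F)F)CC3)C1` gives 14 ug/mL, a gap beyond the scatter. Compound 4 `CN(c1nc2c(c(Nc3ccc(C(F)(F)F)cc3)n1)CCN(c1ncccc1C(F)(F)F)CC2)C1CCCNC1` has methyl(piperidin-3-yl)amino in place of the 4-(pentan-3-yl)piperazin-1-yl of compound 2 on an aromatic carbon (methyl(piperidin-3-yl)amino in place of 4-(pentan-3-yl)piperazin-1-yl on an aromatic carbon). Going by the values given here, one measured step bears on this change: an at least 1.9-fold lower number from compound 1 to compound 2 (0.29 log units; that floor lies within the scatter), which brought in the group that now leaves. Its removal is therefore expected to give only a small rise, a 1.4-fold higher number from compound 2 to compound 4 (0.14 log units; within the scatter). For compound 4 the estimated value is 150 ug/mL, with an expected range from 60 ug/mL to 350 ug/mL.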

Compound 4, solubility: 211 ug/mL
Estimate against measurement, compound 4: 1.4-fold (0.15 log units) below, within the range that was stated.
By their numbers in this assay, from the lowest: compound 3; then compounds 2 and 4 (each within the scatter of the next). At a limit, above all of these: compound 1.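

In this assay, methyl(piperidin-3-yl)amino in place of 4-(pentan-3-yl)piperazin-1-yl on this aromatic carbon gives a 1.9-fold higher number from compound 2 to compound 4 (0.29 log units; within the scatter), so this position takes a hydrogen-bond donor and a smaller group without a change beyond the scatter. Compound 1 gives > 215 ug/mL, which is a limit of the assay and not a number. The remaining step is an at least 1.0-fold lower number from compound 1 to compound 4 (0.00 log units; that floor lies within the scatter), and it cannot be read, as it rests on this limit: the limit of > 215 ug/mL in this assay, at which 1 of the 4 values shown sits.

Open, going by these compounds, is how a carboxylic acid or a morpholine on this aromatic carbon would compare in this assay. Also open, on these data alone, is what the methyl group of compound 4 contributes on its own.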